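The compounds below may be only part of what the source reports. "The series", "measured", "known", "first", "only" and "open" are said of these compounds alone.

Working notes on two hydroxamic acids and a third member of the series. Compound 1 `Cc1cc2cc(NS(=O)(=O)c3cc(C(=O)NO)ccc3Cl)ccc2n(C)c1=O` and compound 2 `COc1ccc(C(=O)NO)cc1CS(=O)(=O)Nc1ccc2c(c1)cc(C)c(=O)n2C` share a common core and differ in the linker and in the substitution pattern of the benzohydroxamic acid. In a functional assay on THP-1 cells (Homo sapiens) for antiproliferative activity, tested at 100 uM (a lower number here means a weaker effect, a higher number a stronger effect of the compound at the concentration tested), compound 1 gives 21%. In this assay compound 2 gives 0%, the lower of the two numbers, with compound 1 standing higher by a margin beyond the usual scatter.

Compound 3 `Cc1cc2cc(NS(=O)(=O)Cc3cccc(C(=O)NO)c3)ccc2n(C)c1=O` has not yet been measured. Relative to compound 2 the change is hydrogen in place of methoxy on an aromatic carbon. For the measured compounds named here, no step between two measured compounds isolates this change, so there is no measured precedent to lean on. The expectation is a step of a number 8 percentage points higher from compound 2 to compound 3 (within the scatter) that stays within the scatter or, at most, a modest rise. The estimated inhibition for compound 3 is 8%, within a range from 0% to 25%.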

Compound 3, a percentage reported as inhibition, at one concentration (the size of the read-out at that concentration, not a potency): 0%
Estimate against measurement, compound 3: 8 percentage points above; measured number inside the range.
By their numbers in this assay, from the lowest: compounds 2 and 3 (each within the scatter of the next); then compound 1.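

In this assay, hydrogen in place of methoxy on this aromatic carbon, para to a hydroxycarbamoyl group, gives no change at the digits printed from compound 2 to compound 3 (within the scatter). For the compounds shown here, this is the first step that isolates this position, and it shows that inhibition at the concentration tested does not appear when methoxy is replaced by hydrogen. Since compound 2 gives 0% and compound 3 gives 0%, the step is read at the bottom of the read-out and says nothing of what this change would do in a compound with measurable inhibition, and no measurement shown here bears on the reason for the result.

As far as these compounds go, whether an amine or a carboxylic acid on this carbon would give measurable inhibition remains open. The higher number of compound 1 also remains unassigned, since it differs from compound 2 in more than one place.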